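Swapping a Hydroxyethyl Chain for a Piperidinyloxy Group

The source may hold more compounds than are shown below. What is called first, only, known or untested is meant among the compounds shown, and "the series" means these compounds.

Among the measured compounds shown here, compound 2 `Cn1cnc2c(C#N)nc(-c3ccc(CCO)c(C(F)(F)F)c3)cc21` gives 71 nM in an assay on isolated protein for inhibition of cathepsin S (Homo sapiens), read by fluorescence (on this read-out higher numbers stand for weaker inhibition and lower numbers for stronger inhibition), the lowest of the two numbers measured so far; compound 1 `COc1ccc(-c2cc3[nH]cnc3c(C#N)n2)cc1C(F)(F)F` gives 339 nM in this assay, a gap that lies beyond the usual scatter. The next compound, compound 3 `Cn1cnc2c(C#N)nc(-c3ccc(OC4CCNCC4)c(C(F)(F)F)c3)cc21`, differs from compound 2 in one place: (piperidin-4-yl)oxy in place of 2-hydroxyethyl on an aromatic carbon. For the measured compounds named here, no pair of measured compounds differs in exactly this way, so there is no earlier step to lean on, and the two measured compounds differ from each other in more than one place. The 2-hydroxyethyl chain gives way to the larger (piperidin-4-yl)oxy group, while the rest of compound 2 is kept. Compound 3 is expected to stay close to compound 2, with a 1.0-fold lower number from compound 2 to compound 3 (0.01 log units; within the scatter) as the estimated step, in no direction beyond the scatter. The estimate for compound 3 in this assay is 70 nM, within a range from 25 nM to 200 nM.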

Compound 3, half-maximal inhibitory concentration: 316 nM
For compound 3 the middle estimate is 4.5-fold (0.65 log units) below the measured one; measured number above the stated range.
By their numbers in this assay, from the lowest: compound 2; then compounds 3 and 1 (each within the scatter of the next).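

In this assay this aromatic carbon, ortho to a trifluoromethyl group, does not accept every group alike: (piperidin-4-yl)oxy in place of 2-hydroxyethyl gives a 4.5-fold higher number from compound 2 to compound 3 (0.65 log units; beyond the scatter) and so weaker inhibition. This is the only single-place change among the compounds shown, which makes it the first direct sign that the group at this position affects the number. The change brings in a ring, a ring nitrogen and more heavy atoms all at once, and no measurement at hand separates these parts or accounts for the loss.

Going by these compounds, what remains open is which part of the new group goes with the weaker inhibition. A longer chain ending in a hydroxyl, a piperidine ring joined directly to the aromatic carbon, or a simple amine at this position would each test a different part of that question.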